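Cytotoxicity on HepG2 cells: indolyl to dimethoxyphenyl replacement

The source may report more compounds than this note shows. Statements on the series, on what has been measured and on what is new or still open speak of the compounds shown alone.

Measured so far:
- compound 1 `CC(C)N(Cc1cccc(OCCCCCC(=O)O)c1)C(=O)c1ccc(-c2ccc3[nH]ccc3c2)cc1`: > 26000 nM
- compound 2 `CC(C)N(Cc1cccc(OCCCCCC(=O)O)c1)C(=O)c1ccc(-c2ccc3cc[nH]c3c2)cc1`: > 26000 nM

Compound 1 `CC(C)N(Cc1cccc(OCCCCCC(=O)O)c1)C(=O)c1ccc(-c2ccc3[nH]ccc3c2)cc1` carries a 1H-indol-5-yl group on the shared core. In an ADME assay on HepG2 cells (Homo sapiens) for cytotoxicity, read by CellTiter-Glo and resazurin assay, with a stated time of 72 h (on this read-out higher numbers stand for an effect only at larger amounts of compound and lower numbers for an effect already at smaller amounts), compound 1 gives > 26000 nM, which is a limit of the assay and not a number. Compound 2 `CC(C)N(Cc1cccc(OCCCCCC(=O)O)c1)C(=O)c1ccc(-c2ccc3cc[nH]c3c2)cc1` carries 1H-indol-6-yl in place of 1H-indol-5-yl on an aromatic carbon. In this assay compound 2 gives > 26000 nM, again a limit of the assay rather than a number. The step that the two limits leave unreadable from compound 1 to compound 2 therefore cannot be sized; both values sit at the limit of > 26000 nM in this assay, at which 2 of the 2 values shown sit. Compound 2 thus stands at the limit, with no further figure to place it.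

Compound 3 `COc1cc(OC)cc(-c2ccc(C(=O)N(Cc3cccc(OCCCCCC(=O)O)c3)C(C)C)cc2)c1` differs from compound 2 by the change (3,5-dimethoxyphenyl in place of 1H-indol-6-yl on an aromatic carbon). For the measured compounds named here, no measured step bears directly on this change, since the only step in this assay is unreadable. With both values at the limit, the expectation for compound 3 in this assay is a step that the limit leaves unreadable from compound 2 to compound 3 that is most likely not readable beyond the scatter. The estimate for compound 3 is 40000 nM with a range from 15000 nM to 120000 nM, with the assay most probably again reporting only a limit.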

Compound 3, half-maximal effective concentration: > 26000 nM
Compound 3 was reported as a limit (the forecaster's own chance of this, stated with the estimate: 75%); the middle value is on the limit's open side.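

In this assay compound 3 gives > 26000 nM, a limit of the assay and not a number. The steps from compound 1 and compound 2 to compound 3 therefore cannot be read: the limit of > 26000 nM in this assay, at which 3 of the 3 values shown sit.

The compounds shown leave open whether 1H-indol-5-yl, 1H-indol-6-yl and 3,5-dimethoxyphenyl differ at all in this assay, and at what concentration any effect would appear.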